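The compounds below may be only part of what the source reports. "The series", "measured", "known", "first", "only" and "open" are said of these compounds alone.

Working notes on the sulfated sugar series in an assay on isolated protein for binding affinity to fibroblast growth factor 1 (Homo sapiens), read by surface plasmon resonance; on this read-out lower numbers stand for tighter binding and higher numbers for weaker binding.

Compound 2 `CO[C@H]1O[C@H](CNC(=O)CN(C(C)=O)C2CCCCCC2)[C@@H](OS(=O)(=O)O)[C@H](OS(=O)(=O)O)[C@@H]1OS(=O)(=O)O` stands at the weak end of the three measured entries: in this assay compound 2 gives 370000 nM. Going by the values given here, its nearest neighbour is compound 1 `CO[C@H]1O[C@H](CNC(=O)CN(Cc2ccccc2)C(C)=O)[C@@H](OS(=O)(=O)O)[C@H](OS(=O)(=O)O)[C@@H]1OS(=O)(=O)O`, which in this assay gives 140000 nM; the single one-point step between them, a 2.6-fold higher number from compound 1 to compound 2 (0.42 log units; beyond the scatter), is the only measured step that touches the amide-type nitrogen being altered here. Compound 3 `CCN(CC(=O)NCCO[C@H]1O[C@H](COS(=O)(=O)O)[C@@H](OS(=O)(=O)O)[C@H](OS(=O)(=O)O)[C@@H]1OS(=O)(=O)O)C(=O)CCCCCCCCCOS(=O)(=O)O`, built on a different arrangement of the same sulfated core, gives 20000 nM in this assay and is the tightest binder of the three.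

Compound 4 `CCN(CC(=O)NC[C@H]1O[C@H](OC)[C@@H](OS(=O)(=O)O)[C@@H](OS(=O)(=O)O)[C@@H]1OS(=O)(=O)O)C(=O)CCCCC(=O)O` arises from compound 2 by the change (((4-carboxybutyl)carbonyl)(ethyl)amino in place of acetyl(cycloheptyl)amino on a saturated chain carbon bound to a carbonyl carbon). Among the compounds with values here, only the step from compound 1 to compound 2 bears on this; it was modest, and the group leaving in compound 4 is the one whose entry cost that step. Within the data shown here, no measured step reports the entering group. Taken as a reversal of the cycloheptyl step, with the carboxyl-bearing chain left unscored, the expected change from compound 2 to compound 4 is a 3.4-fold lower number from compound 2 to compound 4 (0.53 log units; beyond the scatter), toward tighter binding. Compound 4 is therefore estimated at 110000 nM in this assay, within a range from 35000 nM to 350000 nM.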

Compound 4, dissociation constant: 160000 nM
The estimate for compound 4 lay 1.5-fold (0.16 log units) below the measured number, within the range that was stated.
By their numbers in this assay, from the lowest: compound 3; then compounds 1 and 4 (each within the scatter of the next); then compound 2.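

In this assay, the place on a saturated chain carbon bound to a carbonyl carbon accepts a group with no ring: ((4-carboxybutyl)carbonyl)(ethyl)amino in place of acetyl(cycloheptyl)amino gives a 2.3-fold lower number from compound 2 to compound 4 (0.36 log units; beyond the scatter) in a modest step. The same group in place of acetyl(benzyl)amino gives a 1.1-fold higher number from compound 1 to compound 4 (0.06 log units; within the scatter) and so leaves the number where the benzyl-bearing group had it, which means that at this place a ring-bearing group is not needed to reach the level of compound 1. Nothing on hand bears on why either step has the size it has.

Both steps exchange the two substituents on the nitrogen together, so the compounds shown do not separate the contribution of the ethyl group from that of the carboxyl-ended chain. Going by these compounds, it remains open whether the terminal carboxylic acid matters at all, which a methyl ester or a primary amine at the end of the same chain would test, and whether a longer chain carrying the carboxylic acid would move the number beyond the scatter relative to compound 4.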